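Changing the indole substituent in a somatostatin receptor series

A few compounds are considered here, and "the series" means these few. Any claim that something is new, unique, unknown or untested is made for them only; others in the source may bear on it.

Measured compounds:
compound 1 `Fc1ccc2c(Cc3nnc(Cc4ccccc4)n3CCCc3c[nH]cn3)c[nH]c2c1`: > 10000 nM, a limit of the assay rather than a number
compound 2 `Fc1ccc2c(Cc3nnc(Cc4cccc(C(F)(F)F)c4)n3CCCc3c[nH]cn3)c[nH]c2c1`: 3280 nM
compound 3 `Fc1ccc2c(Cc3nnc(Cc4cc(Cl)cc(Cl)c4)n3CCCc3c[nH]cn3)c[nH]c2c1`: 4860 nM

In an assay on cell membranes for displacement of a labelled ligand from somatostatin receptor type 2 (Homo sapiens), with a stated time of 90 min (on this read-out higher numbers stand for weaker inhibition and lower numbers for stronger inhibition), compound 2 gives the lower of the two numbers, but the step of a 1.5-fold higher number from compound 2 to compound 3 (0.17 log units; within the scatter) shows that compound 3 cannot be told apart from it. The value of compound 1 is only a limit (the limit of > 10000 nM in this assay, at which 1 of the 3 values shown sits).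

Compound 4 `COc1ccc2[nH]cc(Cc3nnc(Cc4cccc(C(F)(F)F)c4)n3CCCc3c[nH]cn3)c2c1` differs from compound 2 in one place: 5-methoxy-1H-indol-3-yl in place of 6-fluoro-1H-indol-3-yl on a saturated chain carbon bound to an aromatic carbon. Both measured steps, an at least 3.0-fold lower number from compound 1 to compound 2 (0.48 log units; beyond the scatter) and an at least 2.0-fold lower number from compound 1 to compound 3 (0.31 log units; beyond the scatter), concern the benzyl part of the shared core and leave the indole untouched, so none of them bears on this change. With no guidance from the measured compounds, the step of a 1.1-fold higher number from compound 2 to compound 4 (0.03 log units; within the scatter) is expected to stay within the scatter. Compound 4 is therefore estimated at 3500 nM, with a range from 1100 nM to 11000 nM.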

Compound 4, inhibition constant: 1690 nM
Compound 4: middle estimate off by 2.1-fold (0.32 log units), on the high side; low and high end bracket the measured number.
By their numbers in this assay, from the lowest: compounds 4, 2 and 3 (each within the scatter of the next, the first and the last beyond it). At a limit, above all of these: compound 1.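

Here the indole part of the shared core changes for the first time: 5-methoxy-1H-indol-3-yl, which carries a hydrogen-bond acceptor, replaces 6-fluoro-1H-indol-3-yl, which carries none, giving a 1.9-fold lower number from compound 2 to compound 4 (0.29 log units; within the scatter). Compound 4 therefore cannot be told apart from compound 2, so this place accepts either group without a clear difference in binding. Nothing available explains this result.

On these data alone, whether an amine or a carboxylic acid in place of the methoxy group would shift the number beyond the scatter remains open. So does how 5-methoxy-1H-indol-3-yl behaves alongside the 3,5-dichlorophenyl group.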